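From compound 3 to compound 4: a change on sulfur

The source may report more compounds than this note shows. Statements on the series, on what has been measured and on what is new or still open speak of the compounds shown alone.

Measured in a functional assay on VCaP cells (Homo sapiens) for antiproliferative activity, read by propidium iodide staining, with a stated time of 96 h; on this read-out higher numbers stand for weaker inhibition and lower numbers for stronger inhibition:
Compound 1 `CC(O)(CSc1ccc(F)cc1)C(=O)Nc1ccc(S(F)(F)(F)(F)F)cc1`: 23000 nM
Compound 2 `CC(O)(CSc1cccc(C(F)(F)F)c1)C(=O)Nc1ccc(S(F)(F)(F)(F)F)cc1`: 18800 nM
Compound 3 `CC(O)(CSc1ccccc1C(F)(F)F)C(=O)Nc1ccc(S(F)(F)(F)(F)F)cc1`: 21000 nM

Compound 3 stands level with the other two compounds, as the measured steps show: a 1.1-fold lower number from compound 1 to compound 3 (0.04 log units; within the scatter) and a 1.1-fold higher number from compound 2 to compound 3 (0.05 log units; within the scatter). Compound 4 `CC(O)(CSc1ccc(C(F)(F)F)cn1)C(=O)Nc1ccc(S(F)(F)(F)(F)F)cc1` differs from it in one place, with 5-(trifluoromethyl)pyridin-2-yl in place of 2-(trifluoromethyl)phenyl on a sulfur. The steps above and a 1.2-fold lower number from compound 1 to compound 2 (0.09 log units; within the scatter) all change the group on that sulfur and all lie within the scatter, but none brings in a ring with a hetero atom, so they bear on this change only indirectly. No step beyond the scatter is therefore expected in this assay. The estimated step is a 1.1-fold lower number from compound 3 to compound 4 (0.02 log units; within the scatter). For compound 4 the expected value is 20000 nM, with an estimated range from 9000 nM to 42000 nM.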

Compound 4, half-maximal inhibitory concentration: 19000 nM
Compound 4: middle estimate off by 1.1-fold (0.02 log units), on the high side; low and high end bracket the measured number.
By their numbers in this assay, from the lowest: compounds 2, 4, 3 and 1 (each within the scatter of the next).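

In this assay the 5-(trifluoromethyl)pyridin-2-yl group of compound 4, the only ring on this sulfur with a hetero atom, leaves the number level with all three carbon-only rings: a 1.1-fold lower number from compound 3 to compound 4 (0.04 log units; within the scatter) and a 1.0-fold higher number from compound 2 to compound 4 (0.00 log units; within the scatter) and a 1.2-fold lower number from compound 1 to compound 4 (0.08 log units; within the scatter) all say the same. A ring nitrogen, with its hydrogen-bond acceptor, therefore joins the changes at this position that shift nothing beyond the scatter in this series.

From the compounds shown here alone, whether an amine or a carboxylic acid on the ring, or a plain alkyl chain in its place on sulfur, would move the number remains open. No measurement is available that accounts for this flat result.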